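Ethyl to propyl step in the series

A few compounds are considered here, and "the series" means these few. Any claim that something is new, unique, unknown or untested is made for them only; others in the source may bear on it.

Measured in a functional assay on HT-29 cells (Homo sapiens) for antiproliferative activity, read by MTT assay, with a stated time of 48 h; on this read-out lower numbers stand for stronger inhibition of growth and higher numbers for weaker inhibition of growth:
- compound 1 `CCCOC(=O)N1N=C(c2ccccc2)CC1c1cc(OC)c(OC)c(OC)c1`: > 10000 nM (a limit, not a number)
- compound 2 `CCCOC(=O)N1N=C(c2ccc(OC)cc2)CC1c1cc(OC)c(OC)c(OC)c1`: 12700 nM
- compound 3 `CCOC(=O)N1N=C(c2cccc(O)c2)CC1c1cc(OC)c(OC)c(OC)c1`: 11600 nM

Compound 3 gives 11600 nM and compound 2 gives 12700 nM, and these two values lie within the scatter of each other. Compound 1 reports only a limit, > 10000 nM.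

Compound 4 `CCCOC(=O)N1N=C(c2cccc(O)c2)CC1c1cc(OC)c(OC)c(OC)c1` differs from compound 3 by methyl in place of hydrogen on a saturated chain carbon, two bonds along the chain from an oxygen next to a carbonyl group. This is methyl in place of hydrogen on a saturated chain carbon, two bonds along the chain from an oxygen next to a carbonyl group, or ethoxy to propoxy when cut one bond further out.

Going by the values given here, the only measured step is a step that the limit leaves unreadable from compound 1 to compound 2, and it concerns methoxy in place of hydrogen on an aromatic carbon. It therefore gives no size for the present change. On these data alone, with propoxy, compound 2 gives 12700 nM, so no step beyond the scatter is expected in this assay, and the direction stays open. The estimated step is a 1.0-fold higher number from compound 3 to compound 4 (0.01 log units; within the scatter). Compound 4 is estimated at 12000 nM, with an expected range from 6000 nM to 24000 nM.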

Compound 4, concentration for 50% growth inhibition: 15200 nM
Compound 4: the middle estimate sits 1.3-fold (0.10 log units) below what was measured; the range from low to high includes it.
By their numbers in this assay, from the lowest: compounds 3, 2 and 4 (each within the scatter of the next).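

In this assay, the ethoxy to propoxy change now has a readable size on the shared core carrying 3-hydroxyphenyl: a 1.3-fold higher number from compound 3 to compound 4 (0.12 log units; within the scatter). Going by these compounds alone, at this saturated chain carbon, methyl in place of hydrogen therefore leaves the result within the scatter, which the earlier compounds could not show. With propoxy kept, the other readable step is a 1.2-fold higher number from compound 2 to compound 4 (0.08 log units; within the scatter), so 3-hydroxyphenyl in place of 4-methoxyphenyl on a carbon with a double bond to nitrogen also gives no separation in this assay, and the steps from compound 1 cannot be read, its value of > 10000 nM being a limit and not a number: the limit of > 10000 nM in this assay, at which 1 of the 4 values shown sits.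

The compounds shown leave open whether a longer chain such as butoxy, or a branched chain such as isopropoxy, would produce a step beyond the scatter at this position. Also open, on these data alone, is whether an amine or a carboxylic acid on the phenyl ring in place of hydroxy would separate from compound 4 in this assay.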